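A few compounds are considered here, and "the series" means these few. Any claim that something is new, unique, unknown or untested is made for them only; others in the source may bear on it.

Measured so far:
compound 1 `COc1cc(-c2nc(SCc3cn(CC(=O)NC(=O)Nc4ccccn4)nn3)nc(Nc3ccc(C(C)C)cc3)c2C#N)cc(OC)c1OC` — 1210 nM
compound 2 `COc1cc(-c2nc(SCc3cn(CC(=O)NC(=O)Nc4ccccn4)nn3)nc(Nc3cccc(Cl)c3)c2C#N)cc(OC)c1OC` — 1420 nM

In a functional assay on B16-F10 cells (Mus musculus) for inhibition, read by MTT assay, with a stated time of 72 h (on this read-out lower numbers stand for stronger inhibition and higher numbers for weaker inhibition), compound 1 gives the lowest of the two numbers. Its nearest neighbour is compound 2, and the step of a 1.2-fold higher number from compound 1 to compound 2 (0.07 log units; within the scatter) stays within the scatter, so the two values are not distinguished by this read-out. That step exchanges the group on the anilino nitrogen only; it leaves the rest of the shared core untouched.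

Compound 3 `CC(C)c1ccc(Nc2nc(SCc3cn(CC(=O)NC(=O)Nc4ccccn4)nn3)nc(-c3ccc(Br)cc3)c2C#N)cc1` differs from compound 1 at another place: 4-bromophenyl in place of 3,4,5-trimethoxyphenyl on an aromatic carbon. Among the measured compounds shown here, no measured pair touches this aromatic carbon, so the only step in hand, from compound 1 to compound 2, gives no guide to the size or direction of this change. What is known is that a change elsewhere on the core left the number within the scatter; nothing is known about this position.

The expectation for compound 3 is therefore kept close to compound 1 with a wide range, allowing a step of a 2.3-fold higher number from compound 1 to compound 3 (0.36 log units; beyond the scatter) in either direction. The estimated value for compound 3 in this assay is 2800 nM, from 700 nM to 12000 nM.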

Compound 3, half-maximal inhibitory concentration: 42 nM
Compound 3: the middle estimate sits 67-fold (1.82 log units) above what was measured; measured number outside the range, below it.
By their numbers in this assay, from the lowest: compound 3; then compounds 1 and 2 (each within the scatter of the next).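

In this assay, the aryl group on the aromatic carbon ortho to a cyano group proves to be a strong lever on the number: 4-bromophenyl in place of 3,4,5-trimethoxyphenyl gives a 29-fold lower number from compound 1 to compound 3 (1.46 log units; beyond the scatter), whereas the exchange on the anilino nitrogen gave only a 1.2-fold higher number from compound 1 to compound 2 (0.07 log units; within the scatter). This single pair changes several things together, since a group of 12 heavy atoms with 3 hydrogen-bond acceptors leaves and a group of 7 heavy atoms with 0 hydrogen-bond acceptors enters, so the step belongs to the whole exchange and not to any one feature of it. No measurement in hand bears on why the number moves at this position.

Still open, going by these compounds, is whether the number follows the entering bromine or the departing methoxy groups, which an unsubstituted phenyl, a 4-methoxyphenyl or a 4-chlorophenyl on this carbon would help to separate. Also open, on these data alone, is whether the exchange on the anilino nitrogen stays within the scatter when 4-bromophenyl is present, and how an amine or a carboxylic acid on this aryl ring would read.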